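Dropping the Acid Chain from a Weakly Active Core

This account rests on a few compounds, and the source may have more. Where it says the series, first, only, none or still open, it means among the compounds named here.

Among the compounds with values here, compound 2, `Cn1c(Cc2nn(CCC(=O)O)c(=O)c3ccccc23)nnc1SCCCCCCCC(=O)Nc1ccc(Cl)cc1Cl`, is the only member of this set with a number rather than a limit: in an assay on NK92 cells for inhibition of interleukin-2 (Homo sapiens), read by AlphaScreen, with stated times of 30 min and 1 h (on this read-out lower numbers stand for stronger inhibition and higher numbers for weaker inhibition), compound 2 gives 30000 nM. Compound 1, `Cn1c(Cc2nn(CCCO[Si](C)(C)C(C)(C)C)c(=O)c3ccccc23)nnc1SCCCCCCCC(=O)Nc1ccc(Cl)cc1Cl`, reaches only a limit in this assay, where compound 1 gives > 30000 nM. Within the data shown here, the single measured step, a number no higher from compound 1 to compound 2 (the limit leaves the size open), cannot be sized, since the limit of > 30000 nM in this assay, at which 1 of the 2 values shown sits, caps one of its two values.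

Compound 3, `Cn1c(Cc2n[nH]c(=O)c3ccccc23)nnc1SCCCCCCCC(=O)Nc1ccc(Cl)cc1Cl`, differs from compound 2 in one place: hydrogen in place of 2-carboxyethyl on an aromatic nitrogen. Among the measured compounds shown here, the one measured step touched the far end of the same chain on that aromatic nitrogen and showed no readable effect, so the data give no direction for removing the chain altogether. Compound 3 is therefore expected to stay close to compound 2, and the estimated step of no change at the digits printed from compound 2 to compound 3 (within the scatter) is expected to remain within the scatter. For compound 3 the estimate in this assay is 30000 nM, with a range from 8000 nM to 100000 nM, and with a real chance that the assay returns only a limit.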

Compound 3, half-maximal inhibitory concentration: > 30000 nM
Compound 3 was reported as a limit (the forecaster's own chance of this, stated with the estimate: 50%); the middle value sits exactly at the limit.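

Compound 3, which carries hydrogen on the aromatic nitrogen, gives > 30000 nM in this assay, and this is a limit of the assay, not a number. Removing the 2-carboxyethyl chain entirely therefore yields no measurable gain, and the result reads only as a number no lower from compound 2 to compound 3 (the limit leaves the size open); neither this step nor the one that links the other two limited compounds can be read in size. The earlier compounds had varied this substituent only at the far end of the chain, whereas compound 3 shows that the shared core with no chain on this nitrogen also fails to give a number, leaving no order among the three compounds: the limit of > 30000 nM in this assay, at which 2 of the 3 values shown sit.

The compounds shown leave open whether any substituent on this aromatic nitrogen can bring the assay to a clearly stronger reading, since a chain ending in an amine, a shorter chain ending in a hydroxyl group or a ring-bearing group does not appear among them. They also leave open whether changes elsewhere on the shared core would produce readable differences at this position.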